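Isopropyl to butyl, starting from a limit

The source may report more compounds than this note shows. Statements on the series, on what has been measured and on what is new or still open speak of the compounds shown alone.

In a functional assay on P388 cells (Mus musculus) for cytotoxicity (on this read-out higher numbers stand for an effect only at larger amounts of compound and lower numbers for an effect already at smaller amounts), compound 1 `c1ccc(COc2cc(-c3ccccc3)nc3ccccc23)cc1` gives > 10 ug/mL, which is a limit and not a number. Compound 2 `CC(C)Oc1cc(-c2ccccc2)nc2ccccc12` gives > 10 ug/mL, and this too is a limit. Compound 2 therefore has no numerical position of its own, and the data show only (the limit of > 10 ug/mL in this assay, at which 2 of the 2 values shown sit). The next compound to be measured is compound 3 `CCCCOc1cc(-c2ccccc2)nc2ccccc12`, which carries butyl in place of isopropyl on an oxygen on an aromatic ring. Among the measured compounds shown here, the one measured step that bears on this change concerns the same place on the shared core: a step that the two limits leave unreadable from compound 1 to compound 2. It has no size that can be carried over, so it gives no basis for predicting a change in either direction. The expected change is a step that the limit leaves unreadable from compound 2 to compound 3, with no real shift beyond the scatter anticipated and a further limit the most likely report. For compound 3 the estimated value in this assay is 15 ug/mL, with an expected range from 6 ug/mL to 40 ug/mL.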

Compound 3, half-maximal effective concentration: > 10 ug/mL
Compound 3: no number, only a limit; the forecaster's own chance of this, stated with the estimate: 75%; the middle value is on the limit's open side.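

Compound 3 gives only a limit in this assay, as compound 1 and compound 2 do, so the steps from compound 1 and compound 2 to compound 3 cannot be read: the limit of > 10 ug/mL in this assay, at which 3 of the 3 values shown sit. The compounds shown leave open whether the group on the oxygen changes cytotoxicity at all, and at what concentration any of the three takes effect.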